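Compound 4 and a chlorinated group on the carbonyl

The compounds below may be only part of what the source reports. "The series", "measured", "known", "first", "only" and "open" are said of these compounds alone.

Measured in a functional assay on DU-145 cells (Homo sapiens) for cytotoxicity, read by MTT assay, with a stated time of 68 h; on this read-out lower numbers stand for stronger inhibition and higher numbers for weaker inhibition:
- compound 1 `O=C(/C=C/c1cccc(OCc2ccccc2)c1)c1ccc(Cl)cc1Cl`: 27300 nM
- compound 2 `O=C(/C=C/c1cccc(OCc2ccccc2)c1)c1ccc(O)cc1`: 6300 nM
- compound 3 `O=C(/C=C/c1cccc(OCc2ccccc2)c1)c1ccccc1Br`: 3000 nM

Compound 2, at 6300 nM, has the second highest of the three numbers. Its nearest neighbour is reached by a 2.1-fold lower number from compound 2 to compound 3 (0.32 log units; beyond the scatter), while its furthest lies at the other end of a 4.3-fold lower number from compound 1 to compound 2 (0.64 log units; beyond the scatter).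

Compound 4 `O=C(/C=C/c1cccc(OCc2ccccc2)c1)c1ccc(Cl)c(Cl)c1Cl` has not yet been measured. It carries 2,3,4-trichlorophenyl in place of 4-hydroxyphenyl on a carbonyl carbon.

Among the compounds with values here, compound 1 is the only measured compound that carries chlorine, so a 4.3-fold lower number from compound 1 to compound 2 (0.64 log units; beyond the scatter) bears most directly on this change, read in reverse. It suggests a move to a higher number. Compound 3 goes against any simple halogen trend, since a 2.1-fold lower number from compound 2 to compound 3 (0.32 log units; beyond the scatter) leads to a lower number, and a 9.1-fold lower number from compound 1 to compound 3 (0.96 log units; beyond the scatter) shows how far two halogen-bearing compounds can differ. Three compounds are thin support, so a moderate rise is expected rather than the full distance to compound 1.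

The expected step in this assay is a 2.2-fold higher number from compound 2 to compound 4 (0.35 log units; beyond the scatter). For compound 4 the estimated value is 14000 nM, with an expected range from 4000 nM to 40000 nM.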

Compound 4, half-maximal inhibitory concentration: 6400 nM
Compound 4: the middle estimate sits 2.2-fold (0.34 log units) above what was measured, within the range that was stated.
By their numbers in this assay, from the lowest: compound 3; then compounds 2 and 4 (each within the scatter of the next); then compound 1.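

In this assay, chlorine on the group at the carbonyl carbon does not by itself go with a high number: with chloro in place of hydrogen on an aromatic carbon, the series shows a 4.3-fold lower number from compound 1 to compound 4 (0.63 log units; beyond the scatter), so the third chlorine moves the number down rather than up. Exchanging 4-hydroxyphenyl for 2,3,4-trichlorophenyl removes the hydrogen-bond donor and acceptor counted on that group, yet the read-out stays level, with a 1.0-fold higher number from compound 2 to compound 4 (0.01 log units; within the scatter). The 2-bromophenyl group still keeps the lowest number of the four, since the exchange to 2,3,4-trichlorophenyl gives a 2.1-fold higher number from compound 3 to compound 4 (0.33 log units; beyond the scatter).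

No supporting data accompany these compounds to account for these differences. On these data alone, how an amine or a carboxylic acid would read in place of these groups on the carbonyl carbon remains open.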